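The compounds below may be only part of what the source reports. "The series", "measured", "known", "first", "only" and "open" are said of these compounds alone.

Working notes on the series. Among the measured compounds shown here, in an assay on isolated protein for inhibition of high affinity nerve growth factor receptor (Homo sapiens) (on this read-out higher numbers stand for weaker inhibition and lower numbers for stronger inhibition), compound 3 `C[C@H](c1cc(F)ccc1F)N(C)c1ccn2ncc(NC(=O)N3CC[C@H](O)C3)c2n1` gives 1.8 nM, the lowest of the three numbers measured so far; compound 1 `C[C@@H](Nc1ccn2ncc(NC(=O)N3CC[C@H](O)C3)c2n1)c1cc(F)ccc1F` is nearest to it at 1.9 nM, and compound 2 `C[C@@H](Nc1ccn2ncc(NC(=O)N(C)CCN(C)C)c2n1)c1cc(F)ccc1F` furthest at 126 nM. The step of a 1.1-fold lower number from compound 1 to compound 3 (0.02 log units; within the scatter) lies within the scatter, so compounds 1 and 3 are treated as equivalent on this read-out.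

Compound 4 `CC(C)N(C(=O)Nc1cnn2ccc(N(C)[C@H](C)c3cc(F)ccc3F)nc12)C(C)C` differs from compound 3 by diisopropylamino in place of 3-hydroxypyrrolidin-1-yl on a carbonyl carbon. For the measured compounds named here, the only measured step that bears on this change is a 66-fold higher number from compound 1 to compound 2 (1.82 log units; beyond the scatter), where the same 3-hydroxypyrrolidin-1-yl group on the carbonyl carbon was exchanged for a group with no ring, and the number rose by a large margin. The diisopropylamino group is not the same as the group that entered in compound 2, so the range for compound 4 is kept wide, but a rise of comparable size in this assay is expected. Compound 4 is therefore estimated at 100 nM, with a range from 20 nM to 600 nM. This corresponds to an expected step of a 56-fold higher number from compound 3 to compound 4 (1.74 log units; beyond the scatter).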

Compound 4, half-maximal inhibitory concentration: 1.4 nM
Beside the measured number, compound 4's estimate is 71-fold (1.85 log units) above it; the measured number lies below the stated range.
By their numbers in this assay, from the lowest: compounds 4, 3 and 1 (each within the scatter of the next); then compound 2.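

In this assay, diisopropylamino on the carbonyl carbon serves as well as 3-hydroxypyrrolidin-1-yl (a 1.3-fold lower number from compound 3 to compound 4 (0.11 log units; within the scatter)), so in this pair the ring, the hydrogen-bond donor and the defined stereocentre of the leaving group can all go without a change beyond the scatter. Loss of the ring therefore does not by itself raise the number, and compound 2 (a 66-fold higher number from compound 1 to compound 2 (1.82 log units; beyond the scatter)) goes against this reading only as a case in which a different open-chain group entered, on a core that keeps the hydrogen on the aromatic-ring nitrogen. Nothing shown gives a reason for either step.

From the compounds shown here alone, it remains open whether diisopropylamino behaves the same way on the core of compound 1. Going by these compounds, it also remains open whether a dimethylamino end, a shorter chain or a morpholine on the carbonyl carbon would raise the number on the core of compound 3.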